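This account rests on a few compounds, and the source may have more. Where it says the series, first, only, none or still open, it means among the compounds named here.

Three compounds share one core and differ only in the group attached to a carbonyl carbon. Compound 1 `COc1ccc(OC)c(COc2cc(NC(=O)c3ccc(Br)cc3)ccc2NS(C)(=O)=O)c1` gives 9.58 nM in a functional assay on SK-BR-3 cells (Homo sapiens) for antiproliferative activity, read by MTT assay, with a stated time of 48 h; a higher number here means a weaker inhibitor, a lower number a stronger inhibitor. Compound 2 `COc1ccc(C(=O)Nc2ccc(NS(C)(=O)=O)c(OCc3cc(OC)ccc3OC)c2)cc1` gives 13.4 nM in this assay. Compound 3 `COc1ccc(OC)c(COc2cc(NC(=O)c3ccc(I)cc3)ccc2NS(C)(=O)=O)c1` gives 11.8 nM in this assay. Compound 3 sits among the other two without a clear gap: a 1.2-fold higher number from compound 1 to compound 3 (0.09 log units; within the scatter) and a 1.1-fold lower number from compound 2 to compound 3 (0.06 log units; within the scatter), so the three numbers cannot be told apart in this assay.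

Compound 4 `COc1ccc(OC)c(COc2cc(NC(=O)c3ccc4ccccc4c3)ccc2NS(C)(=O)=O)c1` carries naphthalen-2-yl in place of 4-iodophenyl on a carbonyl carbon. For the measured compounds named here, the steps that bear on this position are a 1.4-fold higher number from compound 1 to compound 2 (0.15 log units; within the scatter), a 1.2-fold higher number from compound 1 to compound 3 (0.09 log units; within the scatter) and a 1.1-fold lower number from compound 2 to compound 3 (0.06 log units; within the scatter); every exchange of one substituent for another at this place has so far left the number within the scatter. Going by the values given here, none of the measured steps adds a second ring, so the change to compound 4 goes beyond what has been tested, but the position has tolerated each variation so far. Compound 4 is therefore expected to show a 1.0-fold higher number from compound 3 to compound 4 (0.01 log units; within the scatter). For compound 4 the estimate is 12 nM, with a range from 5 nM to 30 nM.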

Compound 4, half-maximal inhibitory concentration: 13.3 nM
Estimate against measurement, compound 4: 1.1-fold (0.04 log units) below; measured number inside the range.
By their numbers in this assay, from the lowest: compounds 1, 3, 4 and 2 (each within the scatter of the next).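

For the compounds shown here, the naphthalen-2-yl group is the first change here that adds a second six-membered aromatic ring on the carbonyl carbon, with 10 heavy atoms in place of the 7 of 4-iodophenyl, and in this assay the steps still read a 1.1-fold higher number from compound 3 to compound 4 (0.05 log units; within the scatter), a 1.0-fold lower number from compound 2 to compound 4 (0.00 log units; within the scatter) and a 1.4-fold higher number from compound 1 to compound 4 (0.14 log units; within the scatter). Among the four compounds shown, this place therefore accepts a larger two-ring group as well as a single ring bearing bromo, iodo or methoxy, with no step beyond the scatter. No measurement at hand offers an explanation for this result.

From the compounds shown here alone, all four groups are built on aromatic carbon rings, so it remains open whether the number would hold with an amine, a carboxylic acid or a longer open chain at this place. Going by these compounds, whether a three-ring group such as anthracenyl would stay within the scatter in this assay also remains open.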